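The source may hold more compounds than are shown below. What is called first, only, known or untested is meant among the compounds shown, and "the series" means these compounds.

Compound 3 `CN1C/C(=C\c2ccc(Br)cc2)C(=O)/C(=C/c2ccc(C#N)cc2)C1` gives 4840 nM in a functional assay on HepG2 cells (Homo sapiens) for cytotoxicity, read by MTT assay, with a stated time of 24 h (a higher number here means a weaker inhibitor, a lower number a stronger inhibitor), and stands within the scatter of compound 2 `CN1C/C(=C\c2ccc(F)cc2)C(=O)/C(=C/c2ccc(C#N)cc2)C1` at 6140 nM here. Compound 1 `CN1C/C(=C\c2ccc(C(F)(F)F)cc2)C(=O)/C(=C/c2cccc([N+](=O)[O-])c2)C1` gives 1040 nM as a clearly lower number than either. Compound 4 `CN1C/C(=C\c2ccc(C#N)cc2)C(=O)/C(=C/c2ccc(C(F)(F)F)cc2)C1` follows from compound 3 with trifluoromethyl in place of bromo on an aromatic carbon. Going by the values given here, the one measured step at this place is a 1.3-fold lower number from compound 2 to compound 3 (0.10 log units; within the scatter) for bromo in place of fluoro, and it stays within the scatter. Compound 1 also carries trifluoromethyl, at 1040 nM in the same test, but it has a nitro group where compound 4 has a nitrile, so its number offers only a loose hint. No direct comparison of bromo and trifluoromethyl has been measured. The expected move in this assay is therefore small and towards a lower number, with a 1.3-fold lower number from compound 3 to compound 4 (0.13 log units; within the scatter) as the estimated step, inside the scatter. For compound 4 the estimated value is 3600 nM with an expected range of 1500 nM to 7500 nM around it.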

Compound 4, half-maximal inhibitory concentration: 980 nM
For compound 4 the middle estimate is 3.7-fold (0.57 log units) above the measured one, and the stated range ends above it.
By their numbers in this assay, from the lowest: compounds 4 and 1 (each within the scatter of the next); then compounds 3 and 2 (each within the scatter of the next).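

The earlier step could not separate bromo from fluoro on this aromatic carbon, but trifluoromethyl stands apart from both halogens in this assay (a 4.9-fold lower number from compound 3 to compound 4 (0.69 log units; beyond the scatter) and a 6.3-fold lower number from compound 2 to compound 4 (0.80 log units; beyond the scatter)), each step beyond the scatter. With trifluoromethyl held in place, 4-cyanophenyl and 3-nitrophenyl cannot be told apart (a 1.1-fold lower number from compound 1 to compound 4 (0.03 log units; within the scatter)), a step within the scatter, so the lower numbers of this pair do not depend on which of those two groups is present. Nothing measured here accounts for the gap between trifluoromethyl and the halogens.

As far as these compounds go, whether a methyl group, a methoxy group or an amine on this aromatic carbon would give numbers like those of trifluoromethyl or like those of the halogens remains open. So does whether trifluoromethyl would keep its lead over bromo with a different group at the other end of the shared core.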